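Swapping the dithiocarbamate amine on a benzamide antiproliferative

The compounds below may be only part of what the source reports. "The series", "measured", "known", "first", "only" and "open" are said of these compounds alone.

This account concerns a pair of benzamides bearing a dithiocarbamate arm and follows the step from compound 1 to a compound not yet measured. Compound 1 `Nc1ccccc1NC(=O)c1ccc(CSC(=S)N2CCc3cc(Cl)ccc32)cc1` is the stronger of the two measured compounds: in a functional assay on MGC-803 cells (Homo sapiens) for antiproliferative activity, read by CCK-8 assay, with a stated time of 72 h, tested at 2 uM (a higher number here means a stronger effect of the compound at the concentration tested, a lower number a weaker effect), compound 1 gives 57.7%. Its companion compound 2 `Nc1ccccc1NC(=O)c1ccc(CSC(=S)N2CCN(Cc3ccncc3)CC2)cc1` gives in this assay 18.4%, a gap beyond the usual scatter.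

Compound 3 `CN(Cc1ccncc1)C(=S)SCc1ccc(C(=O)Nc2ccccc2N)cc1` keeps the shared core of compound 1 and differs from it in one place: methyl((pyridin-4-yl)methyl)amino in place of 5-chloro-2,3-dihydro-1H-indol-1-yl on a thiocarbonyl carbon. Going by the values given here, no step between measured compounds isolates this change, so the expectation rests on what the two measured values show. Compound 2, which like compound 3 carries a (pyridin-4-yl)methyl unit on the nitrogen of the thiocarbonyl, sits far below compound 1, so a sizeable fall is expected.

The step from compound 1 to compound 3 is estimated at a number 29.7 percentage points lower from compound 1 to compound 3 (beyond the scatter) in this assay, given that compound 2 gives 18.4%. Compound 3 is therefore expected to give about 28% in this assay, with a plausible range from 12% to 48%.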

Compound 3, a percentage reported as inhibition, at one concentration (the size of the read-out at that concentration, not a potency): 38.1%
Compound 3: middle estimate off by 10.1 percentage points, on the low side; the range from low to high includes it.
By their numbers in this assay, from the lowest: compound 2; then compound 3; then compound 1.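

With this result, the change on the thiocarbonyl carbon can be read directly in this assay: methyl((pyridin-4-yl)methyl)amino in place of 5-chloro-2,3-dihydro-1H-indol-1-yl comes out as a number 19.6 percentage points lower from compound 1 to compound 3 (beyond the scatter), a modest step. The position therefore responds to the choice of amine group, yet the loss of the 5-chloro-2,3-dihydro-1H-indol-1-yl group does not abolish the effect, since compound 3 still gives 38.1% at the concentration tested. No measurement shown here accounts for the size of this step.

The single swap replaces the whole amine group at once, so the compounds shown cannot separate the contribution of the chlorine from that of the surrounding ring system, and a comparison with the unsubstituted 2,3-dihydro-1H-indol-1-yl group or a simple dimethylamino group on the thiocarbonyl carbon would be needed to do so. As far as these compounds go, each read-out also comes from one concentration, so how the potencies of compound 1 and compound 3 compare remains open.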